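This account rests on a few compounds, and the source may have more. Where it says the series, first, only, none or still open, it means among the compounds named here.

Compound 1 `Cc1ccc(S(=O)(=O)Oc2ccccc2/C=C(\C#N)C(=O)Nc2nnc(Cc3cccc4ccccc34)s2)cc1` gives 23% in an ADME assay on HEK-293T cells (Homo sapiens) for inhibition, read by CCK-8 assay, with a stated time of 48 h, tested at 20 uM; a higher number here means more inhibition of growth at the concentration tested, a lower number less inhibition of growth. Compound 2 `COc1ccc(S(=O)(=O)Oc2ccccc2/C=C(\C#N)C(=O)Nc2nnc(Cc3cccc4ccccc34)s2)cc1`, which carries methoxy in place of methyl on an aromatic carbon, gives 29% in this assay, a step of a number 6 percentage points higher from compound 1 to compound 2 (within the scatter). Compound 3 `Cc1ccc(S(=O)(=O)Oc2ccccc2/C=C(\C#N)C(=O)Nc2nnc(Cc3ccc(Cl)cc3)s2)cc1` differs from compound 1 in its core by 4-chlorophenyl in place of naphthalen-1-yl on a saturated chain carbon bound to an aromatic carbon. In this assay compound 3 gives 20%, a step of a number 3 percentage points lower from compound 1 to compound 3 (within the scatter). Compound 4 `COc1ccc(S(=O)(=O)Oc2ccccc2/C=C(\C#N)C(=O)Nc2nnc(Cc3ccc(Cl)cc3)s2)cc1` has not been measured; it differs from compound 3 by methoxy in place of methyl on an aromatic carbon, the same change already made from compound 1 to compound 2, at the same place. For compound 4 in this assay a step of a number 6 percentage points higher from compound 3 to compound 4 (within the scatter) is expected, resting on the earlier step of a number 6 percentage points higher from compound 1 to compound 2 (within the scatter) seen in this assay. Compound 4 is therefore estimated at 26% in this assay, with a likely range from 14% to 38%.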

Compound 4, percent growth inhibition at one concentration: 26%
Estimate against measurement, compound 4: no gap at the digits printed; the measured number falls inside the stated range.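

In this assay, methoxy in place of methyl gives a number 6 percentage points higher from compound 3 to compound 4 (within the scatter), and this agrees with the step on the naphthalen-1-yl core: the same change on two cores in this assay, a number 6 percentage points higher (within the scatter) from compound 1 to compound 2 and a number 6 percentage points higher (within the scatter) from compound 3 to compound 4, 0 percentage points apart, within the scatter of two such steps. The exchange of naphthalen-1-yl for 4-chlorophenyl gives a number 3 percentage points lower from compound 2 to compound 4 (within the scatter), and it agrees in the same way across the methyl and methoxy compounds: the same change on two cores in this assay, a number 3 percentage points lower (within the scatter) from compound 1 to compound 3 and a number 3 percentage points lower (within the scatter) from compound 2 to compound 4, 0 percentage points apart, within the scatter of two such steps. All of these steps lie within the scatter, so the four compounds show that each change reads alike on both cores, but they do not show that either change has a real effect on growth inhibition.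

Open, going by these compounds, is whether a larger step appears with a chlorine or an amine in place of the methyl. Also open, on these data alone, is how a carboxylic acid or a longer chain would read in place of the 4-chlorophenyl.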